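Tert-butyl replaces 3-methylphenyl at a ceiling of activity

A few compounds are considered here, and "the series" means these few. Any claim that something is new, unique, unknown or untested is made for them only; others in the source may bear on it.

Values in a functional assay on NCI/ADR-RES cells (Homo sapiens) for antiproliferative activity, read by MTT assay, with a stated time of 48 h; on this read-out higher numbers stand for weaker inhibition and lower numbers for stronger inhibition (each one a limit of the assay, not a number):
Compound 1 (`C=C1[C@H](OCC(C)C)[C@@H](OC(C)=O)[C@@H](OC(C)=O)C(C)(C)[C@@H]2O[C@H]2[C@H](C)[C@H](OC(=O)c2ccccc2)[C@@]2(O)C[C@@](C)(OC(C)=O)[C@H](OC(C)=O)[C@@H]2[C@H]1OCC(C)C`) > 100000 nM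
Compound 2 (`C=C1[C@H](OC(C)=O)[C@@H](OC(C)=O)[C@@H](OC(C)=O)C(C)(C)/C=C/[C@H](C)[C@H]2O[C@]3(C)C[C@@]2(OC(=O)c2ccccc2)[C@H]([C@H]3OC(C)=O)[C@H]1OCC(C)C`) > 100000 nM
Compound 3 (`C=C1[C@H](OC(C)=O)[C@@H](OC(=O)c2cccc(C)c2)[C@@H](OC(C)=O)C(C)(C)/C=C/[C@H](C)[C@H]2O[C@]3(C)C[C@@]2(OC(=O)c2ccccc2)[C@H]([C@H]3OC(C)=O)[C@H]1OCC(C)C`) > 100000 nM

In this assay compound 3 stands only at the limit > 100000 nM and not at a number. The same is true of all three measured compounds, and the limit of > 100000 nM in this assay, at which 3 of the 3 values shown sit, is the whole of what the data show so far.

The next compound is compound 4 (`C=C1[C@H](OC(C)=O)[C@@H](OC(=O)C(C)(C)C)[C@@H](OC(C)=O)C(C)(C)/C=C/[C@H](C)[C@H]2O[C@]3(C)C[C@@]2(OC(=O)c2ccccc2)[C@H]([C@H]3OC(C)=O)[C@H]1OCC(C)C`). It carries tert-butyl in place of 3-methylphenyl on a carbonyl carbon and keeps the rest of compound 3 unchanged.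

Within the data shown here, only one measured step bears on this change, the one at the same carbonyl carbon with 3-methylphenyl in place of methyl. That step is a step that the two limits leave unreadable from compound 2 to compound 3 and it has no size to carry over. Neither methyl in compound 2 nor 3-methylphenyl in compound 3 lifted the reading off the limit, so tert-butyl is not expected to do so either. In this assay the expected change is none beyond the usual scatter, and the estimated a number no higher from compound 3 to compound 4 (the limit leaves the size open) has no readable direction. Compound 4 is estimated at 100000 nM with an expected range of 50000 nM to 200000 nM in this assay and will most likely be reported only as a limit again.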

Compound 4, half-maximal inhibitory concentration: > 100000 nM
Compound 4 ended at the assay's limit; the forecaster's own chance of this, stated with the estimate: 85%; the middle value lies on the limit itself.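

In this assay compound 4 gives > 100000 nM, again a limit and not a number, so the steps to it from compound 2 and from compound 3 cannot be read. The compounds shown leave open whether any group on this carbonyl carbon changes the activity at all, with every reading at one value: the limit of > 100000 nM in this assay, at which 4 of the 4 values shown sit.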